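This account rests on a few compounds, and the source may have more. Where it says the series, first, only, none or still open, it means among the compounds named here.

Measured so far:
compound 1 `COc1cccc(-c2[nH]c3ccc(C)cc3c2CCC(=O)N2CCN(c3ccccc3OC)CC2)c1`: 8 nM
compound 2 `COc1ccc(-c2[nH]c3ccc(C)cc3c2CCC(=O)N2CCN(c3ccccc3OC)CC2)cc1`: 1.5 nM

In an assay on CHO cells for displacement of a labelled ligand from Substance-P receptor (Homo sapiens) (on this read-out higher numbers stand for weaker inhibition and lower numbers for stronger inhibition), compound 2 stands lowest of the two numbers shown, and the only measured step is a 5.3-fold lower number from compound 1 to compound 2 (0.73 log units; beyond the scatter). Compound 3 `COc1ccccc1N1CCN(C(=O)CCc2c(-c3ccc(-c4ccccc4)cc3)[nH]c3ccc(C)cc23)CC1` differs from compound 2 by phenyl in place of methoxy on an aromatic carbon. Among the measured compounds shown here, no measured step exchanges a methoxy for a phenyl; the single known step merely moves a methoxy from one place to another, so it offers little guidance for this change. A modest step in either direction is therefore expected, and the expected step is a 3.3-fold higher number from compound 2 to compound 3 (0.52 log units; beyond the scatter). Compound 3 is estimated to give 5 nM, within 1 nM to 30 nM.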

Compound 3, half-maximal inhibitory concentration: 7.6 nM
Beside the measured number, compound 3's estimate is 1.5-fold (0.18 log units) below it; the measured number falls inside the stated range.
By their numbers in this assay, from the lowest: compound 2; then compounds 3 and 1 (each within the scatter of the next).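

In this assay, swapping the methoxy for a whole phenyl ring weakens inhibition but does not abolish it, with a 5.1-fold higher number from compound 2 to compound 3 (0.70 log units; beyond the scatter). Among the compounds shown here, this is the first sign that this position accepts a second aromatic ring, although compound 2 keeps the better number. The other step, a 1.1-fold lower number from compound 1 to compound 3 (0.02 log units; within the scatter), shows that 4-phenylphenyl and 3-methoxyphenyl cannot be told apart here.

Nothing available explains these numbers. From the compounds shown here alone, whether a small group at this place, such as a fluorine, a hydroxyl or an amine, would match compound 2 remains open.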